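The source may hold more compounds than are shown below. What is called first, only, known or untested is meant among the compounds shown, and "the series" means these compounds.

Compound 1, `O=C(CCCCC1CCSS1)NCc1cn(CCCOc2ccc3ccc(=O)oc3c2)nn1`, gives 37.8% in a functional assay on PC-12 cells (Rattus norvegicus) for cytotoxicity, read by MTT assay, with stated times of 3 h and 2 h, tested at 0.1 uM; on this read-out lower numbers stand for a weaker effect and higher numbers for a stronger effect at the one concentration tested.
Compound 2, `CC(=O)c1cc2ccc(OCCCn3cc(CNC(=O)CCCCC4CCSS4)nn3)cc2oc1=O`, gives 34.6%.
Compound 3, `O=C(CCCCC1CCSS1)NCc1cn(CCCOc2ccc3cc(-c4ccccc4)c(=O)oc3c2)nn1`, gives 33.9%.

Compound 2 stands second highest of the three numbers. Its nearest neighbour is compound 3, with the step of a number 0.7 percentage points lower from compound 2 to compound 3 (within the scatter), and its furthest is compound 1, with the step of a number 3.2 percentage points lower from compound 1 to compound 2 (within the scatter); neither separates the two compounds from compound 2.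

Compound 4, `O=C(CCCCC1CCSS1)NCc1cn(CCCOc2ccc3cc(-c4ccc(Br)cc4)c(=O)oc3c2)nn1`, is not yet measured. It differs from compound 2 by 4-bromophenyl in place of acetyl on an aromatic carbon.

Among the compounds with values here, two measured steps bear on this change. The step from compound 2 to compound 3 puts a phenyl in place of the acetyl at the same aromatic carbon, and that step was a number 0.7 percentage points lower from compound 2 to compound 3 (within the scatter). The step from compound 1 to compound 3, phenyl in place of hydrogen at the same carbon, was a number 3.9 percentage points lower from compound 1 to compound 3 (within the scatter). Within the data shown here, both are within the scatter, so in this assay no step beyond the scatter is expected for compound 4; the bromine on the phenyl has no measured counterpart here.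

The step from compound 2 to compound 4 is therefore expected to be a number 0.6 percentage points lower from compound 2 to compound 4 (within the scatter). Compound 4 is estimated at 34%, within a range from 25% to 43%.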

Compound 4, a percentage reported as activity, at one concentration (the size of the read-out at that concentration, not a potency): 39.5%
Compound 4: middle estimate off by 5.5 percentage points, on the low side; measured number inside the range.
By their numbers in this assay, from the lowest: compounds 3, 2, 1 and 4 (each within the scatter of the next).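

The 4-bromophenyl group on this aromatic carbon, two atoms from the ring oxygen, replaces acetyl with a step of a number 4.9 percentage points higher from compound 2 to compound 4 (within the scatter) and replaces hydrogen with a step of a number 1.7 percentage points higher from compound 1 to compound 4 (within the scatter), so in this assay neither change separates the compounds. The bromo on the phenyl is the first change shown on that added ring rather than on the shared core, and it gives a number 5.6 percentage points higher from compound 3 to compound 4 (within the scatter), so hydrogen, acetyl, phenyl and 4-bromophenyl at this position are all connected by steps within the scatter. Nothing available explains these small differences or ties them to any property of the groups.

Going by these compounds, whether an amine or a carboxylic acid on this carbon, or a longer chain in place of the acetyl, would give a step beyond the scatter remains open, as does whether a methoxy or a chloro in place of the bromo would do so. The read-out also stands at one concentration, which leaves open how these compounds would compare at other concentrations.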